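Sulfonyl chain truncation in the acyl sulfonamide series

The source may report more compounds than this note shows. Statements on the series, on what has been measured and on what is new or still open speak of the compounds shown alone.

Compound 2 `CC(C)NCCS(=O)(=O)NC(=O)c1ccc(Nc2nc(NC3(c4ccc(Cl)cc4)CC3)nc(OCC(F)(F)F)n2)cc1` gives 100% in an ADME assay on microsomes from liver (Rattus norvegicus) for metabolic stability, with a stated time of 10 min; a higher number here means that more of the compound is left, a lower number that less of the compound is left; compound 1 `CC(C)S(=O)(=O)NC(=O)c1ccc(Nc2nc(NC3(c4ccc(Cl)cc4)CC3)nc(OCC(F)(F)F)n2)cc1` gives 96%, the two within the scatter of each other. Compound 3 `CCS(=O)(=O)NC(=O)c1ccc(Nc2nc(NC3(c4ccc(Cl)cc4)CC3)nc(OCC(F)(F)F)n2)cc1` carries hydrogen in place of isopropylamino on a saturated chain carbon, two bonds along the chain from a sulfonyl sulfur. Among the compounds with values here, the only step on record at this site is a number 4 percentage points higher from compound 1 to compound 2 (within the scatter), a change at the same sulfonyl chain without effect beyond the scatter. Compound 3 is therefore expected to show a number 4 percentage points lower from compound 2 to compound 3 (within the scatter), no shift beyond the scatter. The estimate for compound 3 is 96%, with a range from 86% to 100%.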

Compound 3, percent of the compound remaining: 85%
Compound 3: middle estimate off by 11 percentage points, on the high side; measured number below the stated range.
By their numbers in this assay, from the lowest: compound 3; then compounds 1 and 2 (each within the scatter of the next).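

In this assay, the sulfonyl chain now shows a change beyond the scatter: removing isopropylamino gives a number 15 percentage points lower from compound 2 to compound 3 (beyond the scatter), and removing one methyl gives a number 11 percentage points lower from compound 1 to compound 3 (beyond the scatter). Among these three compounds, the ethyl group on the sulfonyl sulfur is the one that stands apart, while the isopropyl and 2-(isopropylamino)ethyl groups remain within the scatter of each other. Nothing available explains this difference. On these data alone, it remains open whether a methyl, propyl or cyclopropyl group on the sulfonyl sulfur would fall with ethyl or with isopropyl. As far as these compounds go, it also remains open whether a 2-aminoethyl chain would match 2-(isopropylamino)ethyl.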